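This account rests on a few compounds, and the source may have more. Where it says the series, first, only, none or still open, it means among the compounds named here.

Measured so far in a functional assay on MCF7 cells (Homo sapiens) for antiproliferative activity, read by MTT assay, with a stated time of 72 h; a higher number here means a weaker inhibitor, a lower number a stronger inhibitor:
- compound 1 `O=c1oc2cc(O)ccc2cc1-c1ccc(O)c(F)c1`: > 100000 nM, a limit and not a number
- compound 2 `CCc1c(-c2ccc(O)c(F)c2)c(=O)oc2cc(O)ccc12`: 50000 nM

For the measured compounds named here, compound 2 holds the only true number. Compound 1 stands at a limit, (the limit of > 100000 nM in this assay, at which 1 of the 2 values shown sits).

Next is compound 3 `O=c1oc2cc(O)ccc2c(-c2ccc(O)c(F)c2)c1-c1ccc(O)c(F)c1`, with 3-fluoro-4-hydroxyphenyl in place of ethyl on an aromatic carbon, opposite the ring oxygen: 3-fluoro-4-hydroxyphenyl in place of ethyl on an aromatic carbon.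

Going by the values given here, one measured step bears on this place, an at least 2.0-fold lower number from compound 1 to compound 2 (0.30 log units; that floor lies within the scatter). It is only a floor, and it gives no size for a change from ethyl to a ring. Among the compounds with values here, no measured compound carries a ring at this place. With so little to go on, no step beyond the scatter is expected in this assay. The expected change is a 1.4-fold lower number from compound 2 to compound 3 (0.15 log units; within the scatter). Compound 3 is estimated at 35000 nM, with an expected range of 9000 nM to 100000 nM.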

Compound 3, half-maximal inhibitory concentration: 40100 nM
Estimate against measurement, compound 3: 1.1-fold (0.06 log units) below; low and high end bracket the measured number.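

In this assay, for the compounds shown here, the place opposite the ring oxygen takes a group of 8 heavy atoms as well as ethyl: 3-fluoro-4-hydroxyphenyl in place of ethyl gives a 1.2-fold lower number from compound 2 to compound 3 (0.10 log units; within the scatter), so these two groups are not told apart here. 3-Fluoro-4-hydroxyphenyl in place of hydrogen gives an at least 2.4-fold lower number from compound 1 to compound 3 (0.39 log units; beyond the scatter), the first step at this place to clear the scatter. Compound 1 stands at a limit and not a number, so that step is only a floor: the limit of > 100000 nM in this assay, at which 1 of the 3 values shown sits.

Open, going by these compounds, is whether an amine, a carboxylic acid or a longer chain at this place would read as ethyl and 3-fluoro-4-hydroxyphenyl do. Also open, on these data alone, is how plain phenyl would compare with 3-fluoro-4-hydroxyphenyl, a comparison that would separate the ring from its fluorine and hydroxyl.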